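The compounds below may be only part of what the source reports. "The series", "measured", "known", "first", "only" and "open" are said of these compounds alone.

The three measured compounds share one core bearing either a chloro or a nitro group together with a five-membered heteroaromatic ring. Compound 1 `Cc1noc(-c2cc3cc(Cl)ccc3[nH]2)n1` carries a methyl on that ring, and in a functional assay on Jurkat cells (Homo sapiens) for antiproliferative activity, read by WST assay, with a stated time of 72 h (a lower number here means a stronger inhibitor, a higher number a weaker inhibitor), compound 1 gives 21600 nM. Compound 2 `O=[N+]([O-])c1ccc2[nH]c(-c3nc(-c4ccccc4)no3)cc2c1` carries a phenyl and a nitro group. In this assay compound 2 reaches only the limit > 50000 nM, a bound rather than a number. Compound 3 `Clc1ccc2[nH]c(-c3nc(-c4ccccc4)no3)cc2c1` combines the chloro with the phenyl. Compound 3 also stands at the limit > 50000 nM, so only a bound is known for it. Two of the three values sit at the limit of > 50000 nM in this assay, at which 2 of the 3 values shown sit. The readable step, an at least 2.3-fold higher number from compound 1 to compound 3 (0.36 log units; beyond the scatter), runs toward weaker inhibition, whereas a step that the two limits leave unreadable from compound 2 to compound 3. Compound 4 `COc1ccc(-c2noc(-c3cc4cc(Cl)ccc4[nH]3)n2)cc1` differs from compound 3 by methoxy in place of hydrogen on an aromatic carbon. Within the data shown here, no measured step involves a methoxy, so the data offer no direct guide to the size of this change in this assay. Compound 4 is therefore expected to show no step beyond the scatter, a step that the limit leaves unreadable from compound 3 to compound 4, with an estimated value of 60000 nM in a range from 15000 nM to 200000 nM, most probably reported again only as a limit.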

Compound 4, half-maximal inhibitory concentration: > 50000 nM
Compound 4: a limit, no number; the forecaster's own chance of this, stated with the estimate: 75%; the middle value does not contradict the limit.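

Compound 3 and compound 4 both stand only at a limit in this assay, so no step between them can be read: the limit of > 50000 nM in this assay, at which 3 of the 4 values shown sit.

The compounds shown leave open whether methoxy in place of hydrogen on an aromatic carbon changes the activity at all.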